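Isobutyl to phenyl: working notes on compound 3

The source may report more compounds than this note shows. Statements on the series, on what has been measured and on what is new or still open speak of the compounds shown alone.

Measured so far in a functional assay on EOL1 cells (Homo sapiens) for inhibition, read by fluorescence, with a stated time of 72 h; a higher number here means a weaker inhibitor of growth, a lower number a stronger inhibitor of growth (values below)
- compound 1 `CC(C)=CCn1cnc2c(Nc3cccc(Cl)c3)nc(N[C@H]3CC[C@H](N)CC3)nc21` gives 80 nM
- compound 2 `CC(C)CCn1cnc2c(Nc3cccc(Cl)c3)nc(N[C@H]3CC[C@H](N)CC3)nc21` gives 60 nM

For the measured compounds named here, compound 2 (60 nM) holds the lower of the only two numbers available, but it sits within the scatter of compound 1 (80 nM), so the pair sets no real order. The next compound to be tested is compound 3 `N[C@H]1CC[C@H](Nc2nc(Nc3cccc(Cl)c3)c3ncn(Cc4ccccc4)c3n2)CC1` and it differs from compound 2 as follows: phenyl in place of isobutyl on a saturated chain carbon bound to an aromatic nitrogen (phenyl in place of isobutyl on a saturated chain carbon bound to an aromatic nitrogen, which can also be read as isopentyl to benzyl). Going by the values given here, the one measured step at this place is a 1.3-fold lower number from compound 1 to compound 2 (0.12 log units; within the scatter) and it offers only indirect guidance. Among the compounds with values here, no measured compound carries a ring on this chain, so the data give no direct reading for the phenyl group. In this assay a small rise is therefore expected, with a wide margin, and no step beyond the scatter is predicted. The expected step is a 1.5-fold higher number from compound 2 to compound 3 (0.18 log units; within the scatter) as an estimate. For compound 3 the estimated value is 90 nM (estimated range 30 nM to 270 nM).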

Compound 3, concentration for 50% growth inhibition: 380 nM
Beside the measured number, compound 3's estimate is 4.2-fold (0.63 log units) below it; the whole stated range lies below it.
By their numbers in this assay, from the lowest: compounds 2 and 1 (each within the scatter of the next); then compound 3.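

In this assay, the earlier pair gave no sign that this place, a saturated chain carbon bound to an aromatic nitrogen, responds to the group it carries, since isobutyl and 2-methylprop-1-en-1-yl could not be told apart. Phenyl changes that reading, with the number moving beyond the scatter in both available comparisons (a 6.3-fold higher number from compound 2 to compound 3 (0.80 log units; beyond the scatter)) and (a 4.8-fold higher number from compound 1 to compound 3 (0.68 log units; beyond the scatter)), so this place does respond to at least one change of group, read also as isopentyl to benzyl. Nothing available accounts for the step, and the numbers alone give no cause for it.

The compounds shown leave open whether the higher number goes with a ring at this place in general or with the aromatic phenyl ring in particular, and a cyclohexyl ring or a pyridine ring in place of phenyl would separate those two readings. They also leave open whether moving phenyl further out on a longer chain, as in phenethyl, or adding an amine or a carboxylic acid to the ring would keep the number this high.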